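The source may hold more compounds than are shown below. What is called first, only, known or untested is meant among the compounds shown, and "the series" means these compounds.

Measured compounds: compound 1 `CCN1CC=C(c2c[nH]c3ccc(NC(=O)c4ccc(F)cc4)nc23)CC1` gives 25 nM in an assay for binding affinity to 5-hydroxytryptamine receptor 1F (Homo sapiens), read by radioligand binding; on this read-out higher numbers stand for weaker inhibition and lower numbers for stronger inhibition; compound 2 `CCCN1CCC(c2c[nH]c3ccc(NC(=O)c4ccc(F)cc4)nc23)CC1` gives 18 nM in this assay.

Compound 2 has the lowest number of the two in this assay, with compound 1 nearest at a 1.4-fold lower number from compound 1 to compound 2 (0.14 log units; within the scatter). Compound 3 `O=C(Nc1ccc2[nH]cc(C3CCNCC3)c2n1)c1ccc(F)cc1` differs from compound 2 by hydrogen in place of propyl on an amine nitrogen in a ring. Going by the values given here, the only step measured, the one from compound 1 to compound 2, alters the ring and its chain together and lies within the scatter, so it gives little guidance on removing the chain altogether. Compound 3 is therefore expected to show a step of a 1.7-fold higher number from compound 2 to compound 3 (0.22 log units; within the scatter) in this assay, no larger than the scatter, with an estimate of 30 nM in the range 10 nM to 90 nM.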

Compound 3, inhibition constant: 9.5 nM
Beside the measured number, compound 3's estimate is 3.2-fold (0.50 log units) above it, and the stated range ends above it.
By their numbers in this assay, from the lowest: compounds 3, 2 and 1 (each within the scatter of the next, the first and the last beyond it).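

With hydrogen in place of propyl on the amine nitrogen in the ring, this assay shows a 1.9-fold lower number from compound 2 to compound 3 (0.28 log units; within the scatter), so at this position the propyl chain is not needed to keep the number at this level. The wider change of group gives a 2.6-fold lower number from compound 1 to compound 3 (0.42 log units; beyond the scatter), the only step among these compounds beyond the scatter, but it alters the ring and its chain together. No measurement offered here explains these numbers.

As far as these compounds go, whether a methyl, a longer chain or an acetyl group on that nitrogen would keep this level remains open. So does how much of the step from the group of compound 1 belongs to the ring and how much to the chain.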